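Swapping the Amide Ring on a Weakly Antiproliferative Core

The source may report more compounds than this note shows. Statements on the series, on what has been measured and on what is new or still open speak of the compounds shown alone.

Compound 1 `O=C(Nc1ccc(Cl)c(-c2nnc3c(Cl)cccn23)c1)c1ccccn1` and compound 2 `O=C(Nc1ccc(Cl)c(-c2nnc3c(Cl)cccn23)c1)c1ccon1` share one core and differ only in the ring joined to the carbonyl carbon. In a functional assay on MDA-MB-231 cells (Homo sapiens) for antiproliferative activity, read by MTT assay, with stated times of 72 h and 4 h (a higher number here means a weaker inhibitor, a lower number a stronger inhibitor), compound 1 gives 92000 nM. For compound 2 the measurement reports only a limit, > 100000 nM, so no number is known for it. The step of an at least 1.0-fold higher number from compound 1 to compound 2 (0.03 log units; that floor lies within the scatter) therefore cannot be pinned down. The relevant boundary is the limit of > 100000 nM in this assay, at which 1 of the 2 values shown sits.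

Compound 3 `O=C(Nc1ccc(Cl)c(-c2nnc3c(Cl)cccn23)c1)c1ccccc1Cl` is the next member of the series: 2-chlorophenyl in place of 1,2-oxazol-3-yl on a carbonyl carbon. Among the compounds with values here, the only measured step, from pyridin-2-yl to 1,2-oxazol-3-yl, gave no readable change, and both measured compounds are weak inhibitors in this assay. The entering 2-chlorophenyl ring differs from both measured rings, and nothing measured here speaks for a large shift in either direction. Compound 3 is therefore expected to remain in the same weak region, with the estimated step of an at least 1.1-fold lower number from compound 2 to compound 3 (0.04 log units; that floor lies within the scatter) small. The estimate for compound 3 in this assay is 90000 nM, expected to fall between 30000 nM and 300000 nM, and a limit instead of a number is quite possible.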

Compound 3, half-maximal inhibitory concentration: 59900 nM
For compound 3 the middle estimate is 1.5-fold (0.18 log units) above the measured one; measured number inside the range.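

Compound 3 carries a ring of carbon only on the carbonyl carbon, and in this assay compound 3 gives a true number, 59900 nM, which shows that this position accepts 2-chlorophenyl without losing the weak activity seen with pyridin-2-yl. Exchanging pyridin-2-yl for 2-chlorophenyl gives a 1.5-fold lower number from compound 1 to compound 3 (0.19 log units; within the scatter), so the two rings cannot be told apart here, even though one ring holds a nitrogen and the other holds only carbon with a chlorine on it. The step from 1,2-oxazol-3-yl to 2-chlorophenyl is an at least 1.6-fold lower number from compound 2 to compound 3 (0.22 log units; that floor lies within the scatter), and it stays a floor rather than a true size because one end of it is a limit: the limit of > 100000 nM in this assay, at which 1 of the 3 values shown sits.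

From the compounds shown here alone, all three rings leave the series in the same weak region, so it remains open whether any group on this carbonyl carbon can bring a much lower number. Neither an amine, a carboxylic acid nor a longer carbon chain appears here in place of the ring, and a plain phenyl ring, which would show what the chlorine of 2-chlorophenyl contributes, is also absent from the compounds shown.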